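Methylating an Azaindole Nitrogen: Effect on Cell Growth Inhibition

The source may hold more compounds than are shown below. What is called first, only, known or untested is meant among the compounds shown, and "the series" means these compounds.

Compound 1 `O=C(Nc1ccc(Oc2ccnc3[nH]ccc23)cc1)c1cc2cccnc2n(-c2ccc(Cl)cc2)c1=O` gives 290 nM in a functional assay on A549 cells (Homo sapiens) for antiproliferative activity, read by MTT assay, with a stated time of 72 h; a higher number here means a weaker inhibitor, a lower number a stronger inhibitor.
Compound 2 `O=C(Nc1ccc(Oc2ccnc3[nH]ccc23)cc1)c1cc2cccnc2n(-c2ccc(Br)cc2)c1=O` gives 280 nM in this assay.
Compound 3 `O=C(Nc1ccc(Oc2ccnc3[nH]ccc23)cc1)c1cc2cccnc2n(-c2ccc(C(F)(F)F)cc2Cl)c1=O` gives 3230 nM in this assay.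

Compound 2 has the lowest number of the three, but compound 1 sits so close that the two cannot be told apart, as a 1.0-fold lower number from compound 1 to compound 2 (0.02 log units; within the scatter) shows. Compound 3 stands clearly apart: a 12-fold higher number from compound 2 to compound 3 (1.06 log units; beyond the scatter) and an 11-fold higher number from compound 1 to compound 3 (1.05 log units; beyond the scatter) are large steps toward weaker inhibition.

Compound 4 `Cn1ccc2c(Oc3ccc(NC(=O)c4cc5cccnc5n(-c5ccc(Br)cc5)c4=O)cc3)ccnc21` differs from compound 2 by methyl in place of hydrogen on an aromatic nitrogen. Among the measured compounds shown here, none of the measured steps touches this position; all three concern the aryl group on the other nitrogen of the shared core, so they give no direct guide. Without a bearing step, the expectation stays broad: a modest move toward a higher number is estimated for compound 4, with a 2.5-fold higher number from compound 2 to compound 4 (0.40 log units; beyond the scatter) as the central guess, though a change within the scatter is also possible. Compound 4 is expected to give 700 nM, between 150 nM and 3500 nM.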

Compound 4, half-maximal inhibitory concentration: 680 nM
For compound 4 the middle estimate is 1.0-fold (0.01 log units) above the measured one; low and high end bracket the measured number.
By their numbers in this assay, from the lowest: compounds 2 and 1 (each within the scatter of the next); then compound 4; then compound 3.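

Among the compounds shown here, replacing the hydrogen with methyl on this nitrogen of the five-membered aromatic ring is the first change at this position, and in this assay it gives a 2.4-fold higher number from compound 2 to compound 4 (0.39 log units; beyond the scatter). The position therefore responds to this small addition, but the step is modest, whereas the change of aryl group on the other nitrogen gives a large one, a 12-fold higher number from compound 2 to compound 3 (1.06 log units; beyond the scatter). No measurement here explains why the number rises.

The compounds shown leave open whether an ethyl group, a longer chain or a chain ending in an amine on this nitrogen would raise the number further or bring it back down. They also leave open whether methyl would give a step of the same size with the 4-chlorophenyl group of compound 1 in place of the 4-bromophenyl group.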